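A few compounds are considered here, and "the series" means these few. Any claim that something is new, unique, unknown or untested is made for them only; others in the source may bear on it.

Measured so far in a functional assay on MCF7 cells (Homo sapiens) for cytotoxicity, read by MTT assay, with a stated time of 72 h; on this read-out higher numbers stand for weaker inhibition and lower numbers for stronger inhibition:
compound 1 `Cc1cccc(-c2ccnc(C(=O)Nc3ccc(Oc4ccnc5[nH]ccc45)c(F)c3)c2)c1` gives 9120 nM
compound 2 `Cc1ccc(-c2ccnc(C(=O)Nc3ccc(Oc4ccnc5[nH]ccc45)c(F)c3)c2)cc1` gives 8430 nM

Among the measured compounds shown here, compound 2 is one of two measured compounds on the shared core, and the only other number, that of compound 1, sits within the scatter of it: the one step between them, a 1.1-fold lower number from compound 1 to compound 2 (0.03 log units; within the scatter), moves the tolyl methyl from one aromatic carbon to another without a change beyond the scatter.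

Compound 3 `Cc1ccc(-c2ccnc(C(=O)Nc3ccc(Oc4ccnc5[nH]ccc45)c(F)c3)c2)c(C)c1` takes the next step from compound 2: methyl in place of hydrogen on an aromatic carbon. For the measured compounds named here, no measured pair bears directly on a second methyl on that ring; the sole measured step is the positional one just named, and it was within the scatter. Nothing in these two numbers points to a direction for the added methyl, so no step beyond the scatter is expected in this assay, the estimated change being a 1.1-fold lower number from compound 2 to compound 3 (0.02 log units; within the scatter).

For compound 3 in this assay the estimate is 8000 nM, expected between 3000 nM and 22000 nM.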

Compound 3, half-maximal inhibitory concentration: 6220 nM
Compound 3: middle estimate off by 1.3-fold (0.11 log units), on the high side; measured number inside the range.
By their numbers in this assay, from the lowest: compounds 3, 2 and 1 (each within the scatter of the next).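

The step to 2,4-dimethylphenyl reads a 1.4-fold lower number from compound 2 to compound 3 (0.13 log units; within the scatter) in this assay. A second methyl is therefore taken up on the aromatic carbon ortho to a large group and meta to a methyl group without a change beyond the scatter, whereas the earlier pair only moved a single methyl. Against the 3-methylphenyl compound the same ring reads a 1.5-fold lower number from compound 1 to compound 3 (0.17 log units; within the scatter), so all three methyl patterns on this ring stay within the scatter of one another, and no other measurement shown bears on this result.

Open, on these data alone, is whether a group other than methyl at this aromatic carbon, such as a methoxy, an amine or a carboxylic acid, would move the number beyond the scatter in this assay. Also open, as far as these compounds go, is whether a longer chain there would do so.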